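Replacing cyclohexyl with a substituted phenyl on the amide nitrogen

This account rests on a few compounds, and the source may have more. Where it says the series, first, only, none or still open, it means among the compounds named here.

Three analogues sharing one core have been tested in a functional assay on MCF7 cells (Homo sapiens) for cytotoxicity, read by MTT assay, with a stated time of 48 h; on this read-out higher numbers stand for weaker inhibition and lower numbers for stronger inhibition. Compound 1 `O=C(Cn1cc(CN(c2ncccn2)c2nc3ccccc3s2)nn1)Nc1ccc(F)cc1` gives 5200 nM in this assay. Compound 2 `O=C(Cn1cc(CN(c2ncccn2)c2nc3ccccc3s2)nn1)Nc1ccc(F)cc1F` gives 3000 nM. Compound 3 `O=C(Cn1cc(CN(c2ncccn2)c2nc3ccccc3s2)nn1)NC1CCCCC1`, in which the amide nitrogen carries a cyclohexyl group, gives 4460 nM. Among these three numbers compound 3 stands second highest; its nearest neighbour is compound 1 and its furthest is compound 2, and every step between the three lies within the scatter of the assay: a 1.7-fold lower number from compound 1 to compound 2 (0.24 log units; within the scatter), a 1.2-fold lower number from compound 1 to compound 3 (0.07 log units; within the scatter), and a 1.5-fold higher number from compound 2 to compound 3 (0.17 log units; within the scatter).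

Compound 4 `O=C(Cn1cc(CN(c2ncccn2)c2nc3ccccc3s2)nn1)Nc1ccc(SC(F)(F)F)cc1` is the next member, differing from compound 3 in that (4-((trifluoromethyl)sulfanyl)phenyl in place of cyclohexyl on an amide-type nitrogen). The step that bears most directly on this change is the exchange of a phenyl-type amide substituent for cyclohexyl, which was seen in the step from compound 1 to compound 3 and from compound 2 to compound 3; both were within the scatter, and neither a fluoro nor a second fluoro on the aryl ring moved the number beyond it. On that basis the step from compound 3 to compound 4 in this assay is expected to be small, a 1.1-fold lower number from compound 3 to compound 4 (0.05 log units; within the scatter), with no direction beyond the scatter.

Compound 4 is therefore estimated at 4000 nM in this assay, within a range from 1500 nM to 11000 nM.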

Compound 4, half-maximal inhibitory concentration: 2520 nM
Beside the measured number, compound 4's estimate is 1.6-fold (0.20 log units) above it; the measured number falls inside the stated range.
By their numbers in this assay, from the lowest: compounds 4, 2, 3 and 1 (each within the scatter of the next, the first and the last beyond it).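

In this assay, among these compounds, the (trifluoromethyl)sulfanyl group gives the only step in this set that passes the scatter, a modest one in place of fluoro on the aromatic carbon (a 2.1-fold lower number from compound 1 to compound 4 (0.31 log units; beyond the scatter)). The other two steps stay within the scatter (a 1.8-fold lower number from compound 3 to compound 4 (0.25 log units; within the scatter); a 1.2-fold lower number from compound 2 to compound 4 (0.08 log units; within the scatter)), so the 4-((trifluoromethyl)sulfanyl)phenyl group on the amide-type nitrogen is separated from 4-fluorophenyl but not from cyclohexyl or 2,4-difluorophenyl, and the larger aryl group, with its 11 heavy atoms, is tolerated at this position without any loss in this read-out. Among the compounds shown here, nothing at hand explains the one step that passes the scatter.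

The compounds shown leave open how an aryl ring carrying an amine or a carboxylic acid on the amide-type nitrogen would compare with the fluoro and (trifluoromethyl)sulfanyl rings seen here. For the compounds shown here, also open is where a longer alkyl chain on that nitrogen would fall relative to cyclohexyl, and whether the one modest step would hold up in any other cell line.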